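Methyl on the nitrogen: from compound 2 to compound 3

This account rests on a few compounds, and the source may have more. Where it says the series, first, only, none or still open, it means among the compounds named here.

Measured in an ADME assay on MT4 cells (Homo sapiens) for cytotoxicity, read by MTT assay, with a stated time of 4 days; on this read-out lower numbers stand for higher toxicity in this test and higher numbers for lower toxicity in this test:
Compound 1 `Cc1ccc(-c2c(C)c(-c3ccc(C)c(C)c3)c(C(OC(C)(C)C)C(=O)O)c(C)c2NC(=O)c2ccccc2)cc1C`: 9100 nM
Compound 2 `Cc1ccc(-c2c(C)c(-c3ccc(C)c(C)c3)c(C(OC(C)(C)C)C(=O)O)c(C)c2N)cc1C`: 12000 nM

Of the two measured compounds, compound 2 at 12000 nM cannot be told apart from compound 1, whose value is 9100 nM. Among the measured compounds shown here, the only measured step, a 1.3-fold higher number from compound 1 to compound 2 (0.12 log units; within the scatter), puts hydrogen in place of benzoyl on a nitrogen on an aromatic ring.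

Compound 3 `CNc1c(C)c(C(OC(C)(C)C)C(=O)O)c(-c2ccc(C)c(C)c2)c(C)c1-c1ccc(C)c(C)c1` changes that nitrogen again, with methyl in place of hydrogen on a nitrogen on an aromatic ring. For the measured compounds named here, the one step at this nitrogen stayed within the scatter, and it exchanged a benzoyl group rather than a methyl, so it is only a loose guide. Going by the values given here, no measured step yet covers methyl itself. The expected step in this assay is a 1.1-fold lower number from compound 2 to compound 3 (0.04 log units; within the scatter), which would be none beyond the scatter. Compound 3 is estimated at 11000 nM, with an expected range from 6000 nM to 20000 nM.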

Compound 3, half-maximal cytotoxic concentration: 8800 nM
Beside the measured number, compound 3's estimate is 1.3-fold (0.10 log units) above it; measured number inside the range.
By their numbers in this assay, from the lowest: compounds 3, 1 and 2 (each within the scatter of the next).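

In this assay, among the compounds shown here, the first step with methyl itself on this nitrogen gives a 1.4-fold lower number from compound 2 to compound 3 (0.13 log units; within the scatter) and so does not separate the amino and methylamino compounds. Methyl in place of benzoyl gives a 1.0-fold lower number from compound 1 to compound 3 (0.01 log units; within the scatter) and thus closes the set: with hydrogen, methyl or benzoyl on this nitrogen, all three compounds lie within the scatter of one another, so none of these changes registers in this read-out. No supporting data bear on why the three values stay together.

The compounds shown leave open whether an acetyl group or a longer chain such as butyl on this nitrogen would also stay within the scatter. They also leave open what changing the tert-butoxy group or the carboxylic acid would do, as both stand unchanged in all three compounds.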